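Cyano for Fluoro: Estimating Compound 3

This account rests on a few compounds, and the source may have more. Where it says the series, first, only, none or still open, it means among the compounds named here.

Measured compounds:
Compound 1, `O=C(CSc1nnnn1-c1ccccc1)N/N=c1/scc(-c2ccc(F)cc2)n1-c1ccccc1`: 24.3 ug/mL
Compound 2, `O=C(CSc1ncccn1)N/N=c1/scc(-c2ccc(F)cc2)n1-c1ccccc1`: 110 ug/mL

In a functional assay on C6 cells (Rattus norvegicus) for cytotoxicity, read by MTT assay, with a stated time of 24 h (a higher number here means a weaker inhibitor, a lower number a stronger inhibitor), compound 1 gives 24.3 ug/mL, the lowest of the two numbers, and compound 2 gives 110 ug/mL. Within the data shown here, the one measured step, a 4.5-fold higher number from compound 1 to compound 2 (0.66 log units; beyond the scatter), replaces the group on the sulfur with pyrimidin-2-yl in place of 1-phenyl-1H-tetrazol-5-yl.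

Compound 3, `N#Cc1ccc(-c2cs/c(=N/NC(=O)CSc3nnnn3-c3ccccc3)n2-c2ccccc2)cc1`, differs from compound 1 in another part of the molecule: cyano in place of fluoro on an aromatic carbon, that is, 4-fluorophenyl becomes 4-cyanophenyl. Among the measured compounds shown here, no measured step touches this ring, so nothing here shows how this assay responds to that exchange; the only guidance is that compound 1 is the stronger of the two measured compounds and keeps its sulfur group unchanged in compound 3.

Without any step bearing on the change, the expected movement is a 1.1-fold higher number from compound 1 to compound 3 (0.03 log units; within the scatter), that is, nothing beyond the scatter. Compound 3 is therefore estimated at 26 ug/mL, with a range from 8 ug/mL to 85 ug/mL.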

Compound 3, half-maximal inhibitory concentration: > 200 ug/mL
Compound 3: a limit, no number; the forecaster's own chance of this, stated with the estimate: 5%; middle value at least 7.6-fold (0.88 log units) away from the limit.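

This position on the aromatic ring is not a silent one, which the earlier pair could not show, since compounds 1 and 2 differ only in the group on the sulfur. Putting cyano in place of fluoro, with the rest of the molecule unchanged, gives an at least 8.2-fold higher number from compound 1 to compound 3 (0.91 log units; beyond the scatter), so compound 3 is a clearly weaker inhibitor than compound 1 in this assay. On these data alone, compound 3 reads > 200 ug/mL, which is a limit of the assay and not a number, so the full size of the loss stays unknown.

As far as these compounds go, whether an amine or a chlorine at this place would keep the number close to that of compound 1 remains open. Also open, from the compounds shown here alone, are what in the exchange drives the loss and whether it would act the same way with pyrimidin-2-yl on the sulfur.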